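A few compounds are considered here, and "the series" means these few. Any claim that something is new, unique, unknown or untested is made for them only; others in the source may bear on it.

Of the compounds shown here, two built on a shared core have so far been measured in a functional assay on RPMI-8226 cells (Homo sapiens) for inhibition, read by sulforhodamine B assay, with a stated time of 48 h; on this read-out lower numbers stand for stronger inhibition of growth and higher numbers for weaker inhibition of growth. Compound 1, `COc1ccc(-c2ccc(-c3ccc(C(=N)N)o3)o2)cc1`, gives 2680 nM in this assay. Compound 2, `COc1cc(OC)cc(-c2ccc(-c3ccc(C(=N)N)o3)o2)c1`, gives 2250 nM in this assay, and the two numbers lie within the usual scatter of each other, so neither compound can be called the stronger; compound 1 simply holds the higher of the two numbers recorded. Compound 3, `N=C(N)c1ccc(-c2ccc(-c3ccc(F)cc3)o2)o1`, has not yet been measured. It differs from compound 1 in a single place: fluoro in place of methoxy on an aromatic carbon. For the measured compounds named here, no step between two measured compounds shows what this change does, so there is nothing to scale the expectation by. The expected step is a 1.0-fold lower number from compound 1 to compound 3 (0.01 log units; within the scatter), that is, nothing beyond the scatter. For compound 3 in this assay the estimate is 2600 nM, with a range from 1000 nM to 6500 nM.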

Compound 3, concentration for 50% growth inhibition: 2480 nM
For compound 3 the middle estimate is 1.0-fold (0.02 log units) above the measured one; the range from low to high includes it.
By their numbers in this assay, from the lowest: compounds 2, 3 and 1 (each within the scatter of the next).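

In this assay, for the compounds shown here, fluoro in place of methoxy on this aromatic carbon, para to a large group, gives a 1.1-fold lower number from compound 1 to compound 3 (0.03 log units; within the scatter), the first reading of this exchange at this position. At this place, then, taking out the methoxy with its oxygen and putting in fluoro leaves the number within the scatter, so this one change does not separate the two compounds. No measurement shown bears on why the number stays within the scatter.

As far as these compounds go, whether an amine, a carboxylic acid or a longer chain such as butoxy on this same carbon would move the number beyond the scatter remains open. From the compounds shown here alone, it is also open whether fluoro would behave the same way on a ring that carries two methoxy groups, as compound 2 does.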